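The source may hold more compounds than are shown below. What is called first, only, known or untested is meant among the compounds shown, and "the series" means these compounds.

Of the compounds shown here, three of this set have so far been measured in a functional assay on the whole organism (strain Wistar Albino) for inhibition, with Rattus norvegicus as the target, read by paw edema, with a stated time of 2 h, at a dose of 20 mg/kg; a lower number here means less inhibition, a higher number more inhibition at the dose given (going by the name of the read-out). Compound 1 `COc1ccc(Cl)c(-c2nnc3n2NC(c2ccc[nH]2)S3)c1` gives 15.2% in this assay. Compound 3 `COc1ccc(Cl)c(-c2nnc3n2NC(c2cccn2C)S3)c1` carries, relative to compound 1, the change (methyl in place of hydrogen on an aromatic nitrogen). In this assay compound 3 gives 16.8%. The resulting step is a number 1.6 percentage points higher from compound 1 to compound 3 (within the scatter). Compound 2 `COc1ccc(Cc2nnc3n2NC(c2ccc[nH]2)S3)cc1OC` rests on a different core from compound 1; the difference between the two cores is not broken down here. In this assay compound 2 gives 15.9%, a number close to those of compound 1 and compound 3 and within the scatter of both.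

Compound 4 `COc1ccc(Cc2nnc3n2NC(c2cccn2C)S3)cc1OC` has not yet been measured. It stands to compound 2 as compound 3 stands to compound 1, carrying the change (methyl in place of hydrogen on an aromatic nitrogen). The description of the place is identical in both cases, so this is the same change applied on the second core. Because the measured step of a number 1.6 percentage points higher from compound 1 to compound 3 (within the scatter) is small, the step from compound 2 to compound 4 is expected to be small as well, estimated as a number 1.6 percentage points higher from compound 2 to compound 4 (within the scatter). Compound 4 is accordingly expected to give about 17.5% in this assay, with a likely range from 8% to 28%. This expectation rests on a single measured step on a different core and on three measured compounds in all, so it carries limited weight; the actual number for compound 4 remains to be seen.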

Compound 4, a percentage reported as inhibition, in the whole organism at one dose (the size of the read-out at that dose, not a potency): 15.8%
The estimate for compound 4 lay 1.7 percentage points above the measured number; the measured number falls inside the stated range.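

In this assay, methyl in place of hydrogen on an aromatic nitrogen, here 1H-pyrrol-2-yl to 1-methyl-1H-pyrrol-2-yl, gives on the second core a number 0.1 percentage points lower from compound 2 to compound 4 (within the scatter). Set beside the earlier step, the result gives no sign that the two cores respond differently to this change: the same change on two cores in this assay, a number 1.6 percentage points higher (within the scatter) from compound 1 to compound 3 and a number 0.1 percentage points lower (within the scatter) from compound 2 to compound 4, 1.7 percentage points apart, within the scatter of two such steps. For the compounds shown here, both steps lie within the scatter, so this pair of comparisons shows only that the change left no readable mark on the number on either core at this one dose and time; it does not show that the methyl is without consequence in general, nor that the same would hold on a third core or under other conditions, and two pairs are too few to support a rule for the series.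

The compounds shown leave open how larger groups on that same nitrogen, such as an ethyl group, a longer chain or an acetyl group, would read in this assay. They also leave open what an amine or a carboxylic acid would do in place of the chloro group of compound 1 or the methoxy groups of compound 2, where a step beyond the scatter might still appear.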